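The source may hold more compounds than are shown below. What is called first, only, known or untested is meant among the compounds shown, and "the series" means these compounds.

Compound 1, `C=CC1=C(C(=O)NC(C)(C)C)C(c2ccc(OC)cc2)OC1`: > 100000 nM
Compound 2, `C=CC1=C(C(=O)NC(C)(C)C)C(c2ccc(F)cc2)OC1`: > 100000 nM

In a functional assay on QGY7701 cells (Homo sapiens) for cytotoxicity, read by MTT assay, with a stated time of 24 h (on this read-out lower numbers stand for stronger inhibition and higher numbers for weaker inhibition), compound 1 gives only the limit > 100000 nM, so no number fixes where compound 1 stands. Compound 2 likewise gives only the limit > 100000 nM in this assay. The step that the two limits leave unreadable from compound 1 to compound 2 is unreadable because of the limit of > 100000 nM in this assay, at which 2 of the 2 values shown sit. Compound 3, `C=CC1=C(C(=O)NCCCCC)C(c2ccc(OC)cc2)OC1`, differs from compound 1 by pentyl in place of tert-butyl on an amide-type nitrogen. No measured step bears on this change, and the single step shown cannot be sized. Compound 3 is therefore expected to sit near the same limit, with an estimated step that the limit leaves unreadable from compound 1 to compound 3. Compound 3 is estimated at 150000 nM, between 30000 nM and 600000 nM.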

Compound 3, half-maximal inhibitory concentration: > 100000 nM
Compound 3 gave a limit, no number; the forecaster's own chance of this, stated with the estimate: 80%; the middle value is on the limit's open side.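

In this assay compound 3 gives only the limit > 100000 nM, so no step from compound 1 to compound 3 can be read: the limit of > 100000 nM in this assay, at which 3 of the 3 values shown sit.

From the compounds shown here alone, with no number for compound 1, compound 2 or compound 3, it remains open whether pentyl in place of tert-butyl on an amide-type nitrogen changes inhibition at all.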